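A Methoxy Added to Compound 2: Expected Solubility

A few compounds are considered here, and "the series" means these few. Any claim that something is new, unique, unknown or untested is made for them only; others in the source may bear on it.

Measured so far:
compound 1 `CC(=O)NC[C@H]1CN(c2ccc(OC[C@H](O)CNC3CC3)c(F)c2)C(=O)O1`: 2200000 nM
compound 2 `CC(=O)NC[C@H]1CN(c2ccc(OC[C@@H]3CN(c4ccccc4)C(=O)O3)c(F)c2)C(=O)O1`: 14000 nM
compound 3 `CC(=O)NC[C@H]1CN(c2ccc(OC[C@H]3CN(c4ccccc4)C(=O)O3)c(F)c2)C(=O)O1`: 164000 nM

In a physicochemical assay for solubility, read by HPLC (a higher number here means a more soluble compound, a lower number a less soluble compound), compound 2 gives the lowest of the three numbers. The nearest measured step is a 12-fold higher number from compound 2 to compound 3 (1.07 log units; beyond the scatter), and compound 1 lies further still. Among the compounds with values here, that single measured step rests on (the fact that compounds 2 and 3 differ only in the configuration as drawn); no measured pair shows a substituent added to an aromatic ring. Compound 4 `COc1ccc(N2C[C@@H](COc3ccc(N4C[C@H](CNC(C)=O)OC4=O)cc3F)OC2=O)cc1` carries methoxy in place of hydrogen on an aromatic carbon. Within the data shown here, no measured step bears on this change, so no step beyond the scatter is expected in this assay in either direction. For compound 4 the estimate is 12000 nM, with a range from 4000 nM to 40000 nM. That estimate corresponds to a 1.2-fold lower number from compound 2 to compound 4 (0.07 log units; within the scatter), which is expected to remain within the scatter.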

Compound 4, solubility: 132000 nM
Compound 4: middle estimate off by 11-fold (1.04 log units), on the low side; the measured number lies above the stated range.
By their numbers in this assay, from the lowest: compound 2; then compounds 4 and 3 (each within the scatter of the next); then compound 1.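

In this assay, within the data shown here, methoxy in place of hydrogen on an aromatic carbon brings a 9.4-fold higher number from compound 2 to compound 4 (0.97 log units; beyond the scatter) as the first measured step of this kind. It shows that this position, para to a large group, is not silent in this read-out: phenyl to 4-methoxyphenyl moves the number beyond the scatter, and upward. Nothing at hand explains why the number moves. Going by these compounds, whether an amine, a carboxylic acid or a longer chain at this position would move it the same way stays open. So does whether methoxy would have the same effect on compound 3.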